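Two hydroxyl groups on the aromatic ring of compound 1

This account rests on a few compounds, and the source may have more. Where it says the series, first, only, none or still open, it means among the compounds named here.

Compound 1 `C=C/C=C\[C@H](C)[C@H](OC(N)=O)[C@@H](C)[C@H](O)[C@@H](C)C/C(C)=C\[C@H](C)[C@@H](O)[C@@H](C)/C=C\CCc1ccc(C)c(F)c1` has the highest number of the three measured compounds in a functional assay on SK-OV-3 cells (Homo sapiens) for cytotoxicity (a lower number here means a stronger inhibitor, a higher number a weaker inhibitor), giving 1000 nM. Compound 2 `C=C/C=C\[C@H](C)[C@H](OC(N)=O)[C@@H](C)[C@H](O)[C@@H](C)C/C(C)=C\[C@H](C)[C@@H](O)[C@@H](C)/C=C\CCc1cccc(O)c1C` gives 270 nM, and compound 3 `C=C/C=C\[C@H](C)[C@H](OC(N)=O)[C@@H](C)[C@H](O)[C@@H](C)C/C(C)=C\[C@H](C)[C@@H](O)[C@@H](C)/C=C\CCc1cccc(O)c1` gives 40 nM. The change to compound 4 `C=C/C=C\[C@H](C)[C@H](OC(N)=O)[C@@H](C)[C@H](O)[C@@H](C)C/C(C)=C\[C@H](C)[C@@H](O)[C@@H](C)/C=C\CCc1cc(O)cc(O)c1` is 3,5-dihydroxyphenyl in place of 3-fluoro-4-methylphenyl on a saturated chain carbon, two bonds along the chain from a double-bonded chain carbon. The relevant measured steps all point the same way: a 25-fold lower number from compound 1 to compound 3 (1.40 log units; beyond the scatter), a 3.7-fold lower number from compound 1 to compound 2 (0.57 log units; beyond the scatter), and a 6.8-fold lower number from compound 2 to compound 3 (0.83 log units; beyond the scatter). Going by the values given here, a hydroxyl on the ring thus lowers the number strongly, and a methyl beside it is less favourable; a second hydroxyl has no measured precedent here. Compound 4 is therefore expected to show a large drop, a 13-fold lower number from compound 1 to compound 4 (1.10 log units; beyond the scatter), with an estimated value of 80 nM and a range from 20 nM to 400 nM.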

Compound 4, half-maximal inhibitory concentration: 40 nM
For compound 4 the middle estimate is 2.0-fold (0.30 log units) above the measured one; measured number inside the range.
By their numbers in this assay, from the lowest: compounds 3 and 4 (each within the scatter of the next); then compound 2; then compound 1.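

Ring substitution at this position need not stop at one hydroxyl: the rings with one and two hydroxyls read alike (no change at the digits printed from compound 3 to compound 4 (within the scatter)). The 3,5-dihydroxyphenyl ring also holds a clear lead over the two methyl-bearing rings (a 25-fold lower number from compound 1 to compound 4 (1.40 log units; beyond the scatter); a 6.8-fold lower number from compound 2 to compound 4 (0.83 log units; beyond the scatter)). Nothing shown here explains why the ring hydroxyls go with these lower numbers. On these data alone, it remains open whether a methoxy group or an amine on the ring would give numbers as low as the hydroxyl does.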